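A methoxy in place of a sulfur-bearing group on the core

The source may report more compounds than this note shows. Statements on the series, on what has been measured and on what is new or still open speak of the compounds shown alone.

Compound 1, `Nc1ccc(-c2cc(=O)c3c(N)c(F)cc(F)c3o2)cc1F`, was tested in a functional assay on HeLa cells (Homo sapiens) for cytotoxicity, read by neutral red uptake, with a stated time of 3 days; on this read-out higher numbers stand for weaker inhibition and lower numbers for stronger inhibition. In this assay compound 1 gives > 100000 nM, which is a limit of the assay and not a measured number. Compound 2, `C[S+]([O-])c1c(F)c(N)c2c(=O)cc(-c3ccc(N)c(F)c3)oc2c1F`, carries the change a step that the two limits leave unreadable from compound 1 to compound 2. The size of this step cannot be read because the limit of > 100000 nM in this assay, at which 2 of the 2 values shown sit, is where both of the measured values sit. In this assay compound 2 gives > 100000 nM, again a limit of the assay rather than a number. So compound 2 stands at the limit, with no readable step on either side of it.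

Compound 3, `COc1c(F)c(N)c2c(=O)cc(-c3ccc(N)c(F)c3)oc2c1F`, differs from compound 2 by a group of 2 heavy atoms (1 carbon, 1 oxygen; no ring) in place of a group of 3 heavy atoms (1 carbon, 1 oxygen, 1 sulfur; no ring), on an aromatic carbon. Within the data shown here, the only measured step that bears on this change is the one from compound 1 to compound 2, and it is unreadable, so no measured step gives a size or a direction to build on. The expected step that the limit leaves unreadable from compound 2 to compound 3 is therefore none beyond the scatter, with the value most likely staying at the limit. Compound 3 is estimated at 200000 nM, with a range from 60000 nM to 1000000 nM.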

Compound 3, half-maximal inhibitory concentration: 34000 nM
Compound 3: middle estimate off by 5.9-fold (0.77 log units), on the high side, and the stated range ends above it.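

At the aromatic carbon ortho to two fluoro groups, the methoxy of compound 3 gives the first result in this assay that is a number and not a limit, with an at least 2.9-fold lower number from compound 2 to compound 3 (0.46 log units; beyond the scatter). Set against the hydrogen of compound 1, the same methoxy gives an at least 2.9-fold lower number from compound 1 to compound 3 (0.46 log units; beyond the scatter), so a change at this one position can move the read-out beyond the scatter, towards stronger inhibition. The step between compound 1 and compound 2 cannot be read, and the two steps to compound 3 have only a lower bound on their size, because compound 1 and compound 2 both sit at a limit: the limit of > 100000 nM in this assay, at which 2 of the 3 values shown sit.

The compounds shown do not tell whether the shift depends on the oxygen attached to the ring or on the methyl carried by that oxygen, a question that a hydroxyl, an ethoxy or a longer alkoxy chain at this carbon could help to settle. They also leave open how a group with a different first atom, such as an amine or a chlorine atom, would read at the same carbon.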